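The source may report more compounds than this note shows. Statements on the series, on what has been measured and on what is new or still open speak of the compounds shown alone.

Measured so far:
compound 1 `Cc1cc(NS(=O)(=O)c2ccc(-c3cnc(C4CC4)o3)cc2)ccc1Cl` — 33400 nM
compound 2 `O=S(=O)(Nc1cc(F)cc(Cl)c1)c1ccc(-c2cnc(C3CC3)o2)cc1` — 77500 nM

Both numbers come from a functional assay on cells (leukaemia cell line, Homo sapiens) for inhibition, read by sulforhodamine B assay, with a stated time of 48 h; on this read-out lower numbers stand for stronger inhibition of growth and higher numbers for weaker inhibition of growth. Within the data shown here, compound 1 has the lower of the two; its only neighbour is compound 2, reached through a 2.3-fold higher number from compound 1 to compound 2 (0.37 log units; beyond the scatter). Compound 3 `Cc1ccc(Cl)c(NS(=O)(=O)c2ccc(-c3cnc(C4CC4)o3)cc2)c1` is the unmeasured member and differs from compound 1 by 2-chloro-5-methylphenyl in place of 4-chloro-3-methylphenyl on a sulfonamide nitrogen. Among the measured compounds shown here, the one step that bears on it is a 2.3-fold higher number from compound 1 to compound 2 (0.37 log units; beyond the scatter), where changing the substitution of the phenyl on the sulfonamide nitrogen gave a modest rise, so a comparable rearrangement is expected to shift this assay little, at most slightly upward. Compound 3 is therefore estimated at 42000 nM, within 15000 nM to 115000 nM, an expected step of a 1.3-fold higher number from compound 1 to compound 3 (0.10 log units; within the scatter).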

Compound 3, concentration for total growth inhibition: 52800 nM
Estimate against measurement, compound 3: 1.3-fold (0.10 log units) below; low and high end bracket the measured number.
By their numbers in this assay, from the lowest: compounds 1, 3 and 2 (each within the scatter of the next, the first and the last beyond it).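

In this assay the same atoms joined differently on the sulfonamide nitrogen give a 1.6-fold higher number from compound 1 to compound 3 (0.20 log units; within the scatter) and so leave the number within the scatter of compound 1. The change from 3-chloro-5-fluorophenyl to 2-chloro-5-methylphenyl, a 1.5-fold lower number from compound 2 to compound 3 (0.17 log units; within the scatter), also stays within the scatter, so compound 3 cannot be separated from either neighbour. No measurement here bears on why these numbers differ. On these data alone, whether a phenyl carrying an amine or a carboxylic acid at this position would move the number beyond the scatter remains open.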